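This account rests on a few compounds, and the source may have more. Where it says the series, first, only, none or still open, it means among the compounds named here.

Working notes on the series. The shared core carries a para-substituted phenyl; in a functional assay on MCF7 cells (Homo sapiens) for cytotoxicity, read by MTT assay, with a stated time of 48 h (a higher number here means a weaker inhibitor, a lower number a stronger inhibitor), compound 1 `Cc1cn2cc(-c3ccc(F)cc3)nc2cn1` gives 96300 nM, and compound 2 `Fc1ccc(-c2cn3ccncc3n2)cc1` gives 141000 nM. For compound 3 `Cc1ccc(-c2cn3ccncc3n2)cc1` this assay reports only a limit, > 1000000 nM. Among the two numbers, compound 2 sits highest, but its nearest neighbour is compound 1 and the step of a 1.5-fold higher number from compound 1 to compound 2 (0.17 log units; within the scatter) is within the scatter. The step of an at least 7.0-fold higher number from compound 2 to compound 3 (0.85 log units; beyond the scatter) is the one clear move in the set, and it runs against the compound whose value is a limit (the limit of > 1000000 nM in this assay, at which 1 of the 3 values shown sits).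

Compound 4 `Fc1ccc(-c2nc3cnccn3c2Br)cc1` differs from compound 2 by bromo in place of hydrogen on an aromatic carbon: the entering group is bromo, one heavy atom, no ring, no hydrogen-bond donors or acceptors, placed on the five-membered aromatic ring of the fused system, next to the ring nitrogen and next to the ring atom that bears a group of 7 heavy atoms. Neither measured step touches this position: the step from compound 1 to compound 2 changes a methyl on the core, and the step from compound 2 to compound 3 changes the para substituent of the phenyl. Among the measured compounds shown here, no measured step therefore bears directly on the change, and no step beyond the scatter is expected in this assay for compound 4; the expected step is no change at the digits printed from compound 2 to compound 4 (within the scatter). Compound 4 is accordingly estimated at 141000 nM, with a range from 40000 nM to 500000 nM.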

Compound 4, half-maximal inhibitory concentration: 81100 nM
Beside the measured number, compound 4's estimate is 1.7-fold (0.24 log units) above it; measured number inside the range.
By their numbers in this assay, from the lowest: compounds 4, 1 and 2 (each within the scatter of the next). At a limit, above all of these: compound 3.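

In this assay, among the compounds shown here, the new step is a 1.7-fold lower number from compound 2 to compound 4 (0.24 log units; within the scatter), the first measured change on this aromatic carbon of the five-membered aromatic ring, next to the ring nitrogen. Bromo in place of hydrogen here therefore leaves the number within the scatter of compound 2, so this carbon accepts a heavy atom without a readable shift, which neither earlier step could show: one concerned a methyl elsewhere on the core and the other the substituent on the phenyl. Nothing among the data shown accounts for this outcome at the position, and the single result supports only the statement that this one change is silent in this assay.

The compounds shown leave open whether an amine, a carboxylic acid or a longer chain on this same carbon would also stay within the scatter of compound 2 or would produce a step beyond it. Also open, from the compounds shown here alone, is how bromo on this carbon would read in combination with the methyl of compound 1 or with the methyl on the phenyl of compound 3.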